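Bromo in place of methyl: compound 1 to compound 3

A few compounds are considered here, and "the series" means these few. Any claim that something is new, unique, unknown or untested is made for them only; others in the source may bear on it.

Compound 1 `Cc1ccc(N2CCCC2)c(C(=O)Nc2ccc(CNC(=O)OCc3cccnc3)cc2)c1`: 40600 nM
Compound 2 `Cc1cccc(C(=O)Nc2ccc(CNC(=O)OCc3cccnc3)cc2)c1N1CCCC1`: > 100000 nM (a limit of the assay, not a number)

Within the data shown here, in a toxicity assay on WI-38 cells (Homo sapiens) for inhibition, read by MTT assay, with a stated time of 72 h (a lower number here means a stronger inhibitor, a higher number a weaker inhibitor), compound 1 gives 40600 nM, the only actual number among the measured compounds. Compound 2 has only a limit of the assay, > 100000 nM.

Compound 3 `O=C(NCc1ccc(NC(=O)c2cc(Br)ccc2N2CCCC2)cc1)OCc1cccnc1` has yet to be measured in this assay. It differs from compound 1 in one place: bromo in place of methyl on an aromatic carbon. The new group sits para to a pyrrolidin-1-yl group, and the rest of the core of compound 1 is kept.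

Among the measured compounds shown here, no step between measured compounds shows what such an exchange does, so the expectation rests on compound 1 and its 40600 nM. Only a small move toward stronger inhibition is expected, probably within the usual scatter of this assay. The expected change is a 1.4-fold lower number from compound 1 to compound 3 (0.13 log units; within the scatter). For compound 3 the estimated value is 30000 nM, with an expected range from 11000 nM to 80000 nM.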

Compound 3, half-maximal inhibitory concentration: > 100000 nM
Compound 3 ended at the assay's limit (the forecaster's own chance of this, stated with the estimate: 15%); at least 3.3-fold (0.52 log units) between middle value and limit.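

On an aromatic carbon para to a pyrrolidin-1-yl group, bromo in place of methyl gives an at least 2.4-fold higher number from compound 1 to compound 3 (0.39 log units; beyond the scatter) in this assay, so this position responds to a one-atom exchange and the response is toward weaker inhibition. Among these compounds, of the compounds with this substituent pattern, only the one carrying methyl, compound 1, gives an actual number, which means that a readable value at this position so far rests on methyl alone. Compound 3 stands at > 100000 nM, a limit of the assay and not a number, so the step gives only a lower bound on the change, and the ceiling of the assay shapes much of what can be read here: the limit of > 100000 nM in this assay, at which 2 of the 3 values shown sit.

From the compounds shown here alone, how far beyond that limit compound 3 would lie stays open, and so does the true size of the exchange. Whether fluoro, chloro or methoxy on the same aromatic carbon would keep a number within the range of this assay, as methyl does, or would also reach the limit, cannot be told from the compounds shown.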